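The compounds below may be only part of what the source reports. "The series", "measured", "known", "first", "only" and "open" are said of these compounds alone.

Measured so far:

- compound 1, `Cc1ccc(Oc2ccc3nc(COc4cccc(C(=O)O)c4)n(C)c3n2)cc1F`: 5.2 ug/mL
- compound 2, `Cc1ccc(Oc2ccc3nc(COc4cccc(C(=O)O)c4)n(C)c3n2)c(C)c1`: 0.9 ug/mL
- compound 3, `Cn1c(COc2cccc(C(=O)O)c2)nc2ccc(Oc3cccc(Cl)n3)cc21`: 7.7 ug/mL

All three were tested in a physicochemical assay for solubility, read by HPLC, measured as thermodynamic solubility, with a stated time of 4 h, at pH 6.8; on this read-out higher numbers stand for higher solubility and lower numbers for lower solubility. Compound 3 gives 7.7 ug/mL, and compound 1 gives 5.2 ug/mL; these two values lie within the scatter of each other, so no order between them can be claimed. Compound 2 gives 0.9 ug/mL, and the gap from compound 3 down to compound 2 lies beyond the scatter.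

Compound 4, `Cc1ccnc(Oc2ccc3nc(COc4cccc(C(=O)O)c4)n(C)c3c2)c1`, has not yet been measured. It differs from compound 3 by 4-methylpyridin-2-yl in place of 6-chloropyridin-2-yl on an oxygen on an aromatic ring. For the measured compounds named here, the one measured step that touches the same place, the ring on the ether oxygen, is a 5.8-fold lower number from compound 1 to compound 2 (0.76 log units; beyond the scatter), where one substituted phenyl was exchanged for another. That step is only a loose guide, since the present exchange swaps a chlorine for a methyl on a pyridine ring rather than altering a phenyl. With so little to go on, no step beyond the scatter is expected in this assay in either direction. The estimate for compound 4 is therefore 5 ug/mL, with a range from 1.5 ug/mL to 15 ug/mL, which means an expected step of a 1.5-fold lower number from compound 3 to compound 4 (0.19 log units; within the scatter).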

Compound 4, solubility: 33 ug/mL
Estimate against measurement, compound 4: 6.6-fold (0.82 log units) below; the whole stated range lies below it.
By their numbers in this assay, from the lowest: compound 2; then compounds 1 and 3 (each within the scatter of the next); then compound 4.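

In this assay, the ring on the ether oxygen turns out to be a sensitive place on the core of compound 3 as well, and the number can rise there: the exchange of 6-chloropyridin-2-yl for 4-methylpyridin-2-yl gives a 4.3-fold higher number from compound 3 to compound 4 (0.63 log units; beyond the scatter). For the compounds shown here, the only earlier step at this place, a 5.8-fold lower number from compound 1 to compound 2 (0.76 log units; beyond the scatter), went the other way, with one substituted phenyl exchanged for another on a different core, so the direction of a change at this place does not carry over from that pair. The two pyridine groups have the same count of heavy atoms and the same ring, so a clear step appears even when the group keeps its size by that count, though no measurement in hand explains the rise.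

The two groups differ both in the substituent, chlorine against methyl, and in where it sits on the pyridine, so these two changes remain unseparated in this single step. A plain pyridin-2-yl, or an amine or methoxy group on that ring, would show how far the number depends on the substituent, and the same exchange on the core of compound 1 would show whether the step holds there.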